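From Hydroxymethyl to Methoxy on an Amide Side Chain

This account rests on a few compounds, and the source may have more. Where it says the series, first, only, none or still open, it means among the compounds named here.

Of the compounds shown here, two that share a thiophene-bearing amide core have been measured in an assay on HEK293 cells for agonist activity at transient receptor potential cation channel subfamily M member 8 (Homo sapiens), read by fluorescence and calcium flux, with a stated time of 15 min; a higher number here means that more compound is needed for the effect, a lower number that less compound is needed. Compound 1 `CCN(Cc1cccs1)C(=O)C(C)Oc1ccc(C)cc1` gives 889 nM. Compound 2 `Cc1ccc(OCC(=O)N(CCCO)Cc2cccs2)cc1` gives 3000 nM, the highest of the two numbers, and the gap to compound 1 lies beyond the usual scatter.

Compound 3 `COCCN(Cc1cccs1)C(=O)COc1ccc(C)cc1` has not yet been measured. It keeps every atom of compound 2 but joins them differently: methoxy in place of hydroxymethyl on a saturated chain carbon, two bonds along the chain from an amide-type nitrogen.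

Going by the values given here, no measured pair shows this exact change, so its effect can only be guessed from compound 2 alone. The step of a 1.7-fold lower number from compound 2 to compound 3 (0.22 log units; within the scatter) is expected to be modest, toward a lower number, but it may well stay within the scatter. Compound 3 is therefore estimated to give 1800 nM in this assay, with a plausible range from 700 nM to 4500 nM.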

Compound 3, half-maximal effective concentration: 400 nM
Estimate against measurement, compound 3: 4.5-fold (0.65 log units) above; measured number below the stated range.
By their numbers in this assay, from the lowest: compound 3; then compound 1; then compound 2.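

Read as 3-hydroxypropyl to 2-methoxyethyl, this exchange moves no atom in or out, yet it gives a 7.5-fold lower number from compound 2 to compound 3 (0.88 log units; beyond the scatter) in this assay and shows that this chain position is sensitive to how the same atoms are joined. Hydroxymethyl carries 1 hydrogen-bond donor and methoxy carries 0, while each has 1 hydrogen-bond acceptor, and this is the only difference in those counts between the two groups. No supporting measurement is available to tie the shift in the number to that difference or to any other.

From the compounds shown here alone, whether the donor count matters or the placement of the oxygen along the chain matters remains open. An ethoxy group, an amine or a carboxylic acid at the same place could begin to separate these readings, and a longer chain such as 3-methoxypropyl would test how far along the oxygen can sit.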